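Isopropyl to cyclohexyl in a macrocyclic series: metabolic stability

The source may report more compounds than this note shows. Statements on the series, on what has been measured and on what is new or still open speak of the compounds shown alone.

Compound 1 `CC(C)[C@@H]1NC[C@@H](C)Oc2ccccc2CCCNC(=O)[C@@H](Cc2ccc(F)cc2)NC(=O)[C@@H](C)N(C)C1=O` and compound 2 `C[C@@H]1C(=O)N[C@H](Cc2ccc(F)cc2)C(=O)NCCCc2cccc3c2O[C@H](CC3)CN[C@@H](C2CC2)C(=O)N1C` are the two macrocycles measured so far. In an in vivo ADME assay on the whole organism (strain Sprague-Dawley) for metabolic stability, with Rattus norvegicus as the target (a higher number here means that the compound lasts longer, a lower number that the compound disappears faster), compound 1 gives 34 h, and compound 2 gives 59 h; the two numbers lie within the usual scatter of each other, so no ranking between them can be drawn. Compound 3 `C[C@@H]1CN[C@@H](C2CCCCC2)C(=O)N(C)[C@H](C)C(=O)N[C@H](Cc2ccc(F)cc2)C(=O)NCCCc2ccccc2O1` is not yet measured. It differs from compound 1 in one place: cyclohexyl in place of isopropyl on a saturated ring carbon. Among the measured compounds shown here, with no measured step of this kind available, the change is expected to move the half-life by a 1.2-fold higher number from compound 1 to compound 3 (0.07 log units; within the scatter), a step not expected to exceed the scatter. Compound 3 is therefore estimated at 40 h, within a range from 20 h to 80 h.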

Compound 3, half-life: 74 h
Beside the measured number, compound 3's estimate is 1.9-fold (0.27 log units) below it; low and high end bracket the measured number.
By their numbers in this assay, from the lowest: compounds 1, 2 and 3 (each within the scatter of the next, the first and the last beyond it).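

Among the compounds shown here, on the saturated ring carbon next to the ring nitrogen, this assay gives the first single-place step: cyclohexyl in place of isopropyl yields a 2.2-fold higher number from compound 1 to compound 3 (0.34 log units; beyond the scatter) and so lies beyond the scatter. The step is modest, but it shows that the half-life at this position responds to the group carried there. Nothing at hand accounts for the step. Going by these compounds, whether phenyl, tert-butyl or a cyclohexyl bearing an amine would move the half-life further remains open. So does whether the same step would hold on the core of compound 2.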